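Two Aryl Substituents on a Shared Acylurea Core

A few compounds are considered here, and "the series" means these few. Any claim that something is new, unique, unknown or untested is made for them only; others in the source may bear on it.

Two compounds share the same acylurea core and differ in two places. Compound 1 `CCOc1cc(Cl)c(C(=O)NC(=O)Nc2nc3ccc(S(=O)(=O)C4CCN(C)CC4)cc3s2)cc1-n1cccn1` carries a 1H-pyrazol-1-yl group on its central aryl ring. In a functional assay on CHO cells for agonist activity at hydroxycarboxylic acid receptor 1 (Homo sapiens), read by cAMP accumulation (on this read-out higher numbers stand for an effect only at larger amounts of compound and lower numbers for an effect already at smaller amounts), compound 1 gives 23 nM. Compound 2 `CCOc1cc(Cl)c(C(=O)NC(=O)Nc2nc3ccc(CN4CCN(C)CC4)cc3s2)cc1N1CCCC1` carries a pyrrolidin-1-yl group at the same place and a different amine-bearing substituent on the bicyclic part. In this assay compound 2 gives 13 nM; the two values lie within the usual scatter of each other, so no order can be read from them.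

Compound 3 `CCOc1cc(Cl)c(C(=O)NC(=O)Nc2nc3ccc(CN4CCN(C)CC4)cc3s2)cc1-n1cccn1` has not yet been measured. It differs from compound 2 in one place: 1H-pyrazol-1-yl in place of pyrrolidin-1-yl on an aromatic carbon. For the measured compounds named here, no measured pair isolates this exchange, but compound 1 already carries the entering group and gives 23 nM. On that basis the step from compound 2 to compound 3 in this assay is expected to be small, in neither direction beyond the scatter, as a 1.2-fold higher number from compound 2 to compound 3 (0.06 log units; within the scatter). Compound 3 is therefore estimated at 15 nM, with a likely range from 6 nM to 40 nM.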

Compound 3, half-maximal effective concentration: 19 nM
Beside the measured number, compound 3's estimate is 1.3-fold (0.10 log units) below it; measured number inside the range.
By their numbers in this assay, from the lowest: compounds 2, 3 and 1 (each within the scatter of the next).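

Compound 3 separates the two differences that were combined between compound 1 and compound 2. At the aromatic carbon ortho to the ethoxy group, the exchange of the non-aromatic pyrrolidin-1-yl ring for the aromatic 1H-pyrazol-1-yl ring gives a 1.5-fold higher number from compound 2 to compound 3 (0.16 log units; within the scatter) in this assay, while at the other place, (4-methylpiperazin-1-yl)methyl in place of (1-methylpiperidin-4-yl)sulfonyl gives a 1.2-fold lower number from compound 1 to compound 3 (0.08 log units; within the scatter), so neither exchange taken alone moves the number beyond the scatter. There are no accompanying data that could account for this result.

For the compounds shown here, with only two groups seen at each place, it remains open whether the number in this assay would hold with a morpholin-4-yl ring or a phenyl ring at the carbon ortho to the ethoxy group, or with a carboxylic acid or a primary amine in place of the amine-bearing substituent. It also remains open how pyrrolidin-1-yl would read when paired with (1-methylpiperidin-4-yl)sulfonyl, the one combination of these four groups that lies outside the compounds shown.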